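The source may hold more compounds than are shown below. What is called first, only, known or untested is meant among the compounds shown, and "the series" means these compounds.

Compound 3, `CNC(=S)Nc1ccc(S(=O)(=O)Nc2ccc(Br)cc2)cc1`, is the starting point of this step. In a functional assay on the whole organism with Mus musculus as the target, in the maximal electroshock model, with a stated time of 0.5 h (a lower number here means that less compound is needed, a higher number that more compound is needed for the effect), compound 3 gives 300 mg/kg. Among the compounds with values here, that number sets compound 3 level with compound 1, `CNC(=S)Nc1ccc(S(=O)(=O)Nc2ccc(Cl)cc2)cc1`, which in this assay gives 300 mg/kg; together these two stand at the highest of the three numbers measured so far, and the step of no change at the digits printed from compound 1 to compound 3 (within the scatter) shows the two halogens on the aromatic carbon as interchangeable here. Within the data shown here, the remaining measured compound, compound 2, `Cc1ccc(NC(=S)Nc2ccc(S(=O)(=O)Nc3ccc(Cl)cc3)cc2)cc1`, gives 100 mg/kg in this assay, and the step of a 3.0-fold lower number from compound 1 to compound 2 (0.48 log units; beyond the scatter) is the only one of the measured steps that reaches beyond the scatter.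

Compound 4, `Cc1ccc(NC(=S)Nc2ccc(S(=O)(=O)Nc3ccc(Br)cc3)cc2)cc1`, is not yet measured. It differs from compound 3 by 4-methylphenyl in place of methyl on an amide-type nitrogen. The step that bears directly on this change is a 3.0-fold lower number from compound 1 to compound 2 (0.48 log units; beyond the scatter), since it carries the same exchange on an amide-type nitrogen within the chloro series, and the step of no change at the digits printed from compound 1 to compound 3 (within the scatter) gives no sign that the bromo series should respond differently. Compound 4 is therefore expected to show a step of about a 3.0-fold lower number from compound 3 to compound 4 (0.48 log units; beyond the scatter), in the direction of a lower number. On that basis compound 4 is estimated at 100 mg/kg in this assay, with a range from 50 mg/kg to 300 mg/kg.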

Compound 4, minimum effective dose: 100 mg/kg
Beside the measured number, compound 4's estimate shows no gap at the digits printed; low and high end bracket the measured number.
By their numbers in this assay, from the lowest: compounds 2 and 4 (each within the scatter of the next); then compounds 1 and 3 (each within the scatter of the next).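

In this assay, the exchange of methyl for 4-methylphenyl on the amide-type nitrogen now also appears in the bromo series, with a step of a 3.0-fold lower number from compound 3 to compound 4 (0.48 log units; beyond the scatter), so the lower number is no longer seen in the chloro series alone. The size of this step matches the one in the chloro series: the same change on two cores in this assay, a 3.0-fold lower number (0.48 log units; beyond the scatter) from compound 1 to compound 2 and a 3.0-fold lower number (0.48 log units; beyond the scatter) from compound 3 to compound 4, 1.0-fold (0.00 log units) apart, within the scatter of two such steps The interchange of chloro and bromo on the aromatic carbon, earlier seen only with methyl on the nitrogen, now also holds with 4-methylphenyl there, with no change at the digits printed from compound 2 to compound 4 (within the scatter), and across these four compounds the number follows the group on the nitrogen and not the halogen: the same change on two cores in this assay, no change at the digits printed (within the scatter) from compound 1 to compound 3 and no change at the digits printed (within the scatter) from compound 2 to compound 4, 1.0-fold (0.00 log units) apart, within the scatter of two such steps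

The compounds shown leave open whether the lower number comes from the aromatic ring itself or from the methyl it carries, a question that an unsubstituted phenyl, a cyclohexyl or a longer chain such as butyl on the same nitrogen would address. They also leave open whether the aromatic carbon now holding chloro or bromo would tolerate a fluoro, a methoxy or a nitrile equally well.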